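Acetyl to cyclopropylcarbonyl on the aryl ketone of compound 1

This account rests on a few compounds, and the source may have more. Where it says the series, first, only, none or still open, it means among the compounds named here.

Measured so far:
compound 1 `CC(=O)c1ccc(OCCCN2CC[C@H](NC(=O)c3csc(-c4cccnc4)n3)C2)cc1` in an assay on isolated protein for binding affinity to histamine H2 receptor (Homo sapiens); a lower number here means a stronger inhibitor, a higher number a weaker inhibitor: 6200 nM
compound 2 `O=C(c1ccc(OCCCN2CC[C@H](NS(=O)(=O)c3ccc(Cl)cc3)C2)cc1)C1CC1` in this assay: 290 nM

Compound 1 holds the higher of the two numbers; compound 2 gives a lower number, and the gap between them lies beyond the scatter. Among the measured compounds shown here, compound 2 differs from compound 1 in more than one place, so no single step between them can be read.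

Compound 3 `O=C(N[C@H]1CCN(CCCOc2ccc(C(=O)C3CC3)cc2)C1)c1csc(-c2cccnc2)n1` differs from compound 1 in one place: cyclopropyl in place of methyl on a carbonyl carbon. For the measured compounds named here, no measured pair shows this change on its own. A modest step is expected, from compound 1 to compound 3 of about a 2.1-fold lower number from compound 1 to compound 3 (0.32 log units; beyond the scatter), toward a lower number, near the edge of the scatter. Compound 3 is therefore expected to give about 3000 nM in this assay, within 1000 nM to 10000 nM.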

Compound 3, inhibition constant: 4000 nM
Compound 3: middle estimate off by 1.3-fold (0.12 log units), on the low side, within the range that was stated.
By their numbers in this assay, from the lowest: compound 2; then compounds 3 and 1 (each within the scatter of the next).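

On the core of compound 1, cyclopropyl in place of methyl on a carbonyl carbon gives a 1.6-fold lower number from compound 1 to compound 3 (0.19 log units; within the scatter) in this assay. This single-place step shows that the 4-acetylphenyl to 4-(cyclopropylcarbonyl)phenyl change, with its added three-membered ring, does not move the number beyond the scatter. Open questions are whether an isopropyl or tert-butyl group on the same carbonyl carbon would leave the number within the scatter, and whether methyl in place of cyclopropyl on compound 2 would give a similar step. No measurement available here bears on why this step is so small.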